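A Urea in Place of a Thiourea, Near the Assay Limit

The source may hold more compounds than are shown below. What is called first, only, known or untested is meant among the compounds shown, and "the series" means these compounds.

Values in a functional assay on HL-60 cells (Homo sapiens) for inhibition, read by CCK-8 assay, with a stated time of 48 h; on this read-out lower numbers stand for stronger inhibition and higher numbers for weaker inhibition
Compound 1 `COc1ccc(Oc2ccccc2-c2ccsc2S(=O)(=O)N2CCN(C(=O)Nc3cccc([N+](=O)[O-])c3)CC2)cc1OC` gives > 50000 nM (a limit)
Compound 2 `O=C(Nc1ccc(F)cc1)N1CCN(S(=O)(=O)c2sccc2-c2ccccc2Oc2ccc(O)c(O)c2)CC1` gives 8100 nM
Compound 3 `COc1ccc(Oc2ccccc2-c2ccsc2S(=O)(=O)N2CCN(C(=S)Nc3ccc(Cl)cc3)CC2)cc1OC` gives > 50000 nM (a limit)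

In this assay compound 3 gives > 50000 nM, which is a limit and not a number. Compound 3 therefore stands at the limit of > 50000 nM in this assay, at which 2 of the 3 values shown sit. Compound 4 `COc1ccc(Oc2ccccc2-c2ccsc2S(=O)(=O)N2CCN(C(=O)Nc3ccc(F)cc3)CC2)cc1OC` keeps the core of compound 3 and changes only the group on the ring nitrogen: a group of 10 heavy atoms (7 carbon, 1 nitrogen, 1 oxygen, 1 fluorine; one six-membered aromatic ring of carbon only) in place of a group of 10 heavy atoms (7 carbon, 1 nitrogen, 1 sulfur, 1 chlorine; one six-membered aromatic ring of carbon only), on an amine nitrogen in a ring. Among the compounds with values here, one measured step touches this same place, a step that the two limits leave unreadable from compound 1 to compound 3, and both of its ends are limits, so it gives no size to carry over. Within the data shown here, compound 2 is the only one with a true number, 8100 nM, and no measured step links it to the others. Among the measured compounds shown here, with only that unreadable step to go on, no clear change in either direction is expected in this assay. The expected step is an at least 1.1-fold lower number from compound 3 to compound 4 (0.04 log units; that floor lies within the scatter). For compound 4 the estimate is 45000 nM, with an expected range from 15000 nM to 50000 nM.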

Compound 4, half-maximal inhibitory concentration: > 20000 nM
Compound 4 was reported as a limit (the forecaster's own chance of this, stated with the estimate: 70%); the middle value lies beyond the limit too.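

In this assay, within the data shown here, compound 4 gives the first readable link to compound 2, the only compound with a true number: with 3,4-dimethoxyphenyl in place of 3,4-dihydroxyphenyl on an oxygen on an aromatic ring, the result is an at least 2.4-fold higher number from compound 2 to compound 4 (0.39 log units; beyond the scatter). Compound 4 gives > 20000 nM, which is a limit. The steps from compound 3 to compound 4 and from compound 1 to compound 4 cannot be read, so swapping the thiourea for a urea shows no measurable effect here.

The compounds shown leave open whether the urea or the thiourea matters once the 3,4-dihydroxyphenyl group is present. They also leave open whether a single hydroxyl or an amine on that ring would keep the inhibition seen with compound 2.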